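A few compounds are considered here, and "the series" means these few. Any claim that something is new, unique, unknown or untested is made for them only; others in the source may bear on it.

Among the compounds with values here, compound 1 `C=C1C(=O)[C@]23C[C@@]1(O)CC[C@H]2c1ccc(O)c(C)c1[C@@H]3Cn1cc(-c2ccc(C(F)(F)F)cc2)nn1` is the only compound here with a number rather than a limit in a functional assay on A549 cells (Homo sapiens) for cytotoxicity, read by MTT assay, with a stated time of 4 days; on this read-out lower numbers stand for stronger inhibition and higher numbers for weaker inhibition; compound 1 gives 1110 nM. Compound 2 `C=C1C[C@]23C[C@@]1(O)CC[C@@H]2c1cccc(C)c1[C@@H]3Cn1cc(-c2ccc(Cl)cc2)nn1` reaches only a limit of the assay, > 20000 nM, which is what the limit of > 20000 nM in this assay, at which 1 of the 2 values shown sits, records. Compound 3 `C=C1C(=O)[C@]23C[C@@]1(O)CC[C@H]2c1ccc(O)c(C)c1[C@@H]3Cn1cc(-c2ccc(Br)cc2)nn1` differs from compound 1 by bromo in place of trifluoromethyl on an aromatic carbon. Within the data shown here, no measured step of this kind is available, so only a small change is expected, no larger than the usual scatter, in either direction. Compound 3 is therefore estimated at 1400 nM, likely between 500 nM and 4500 nM. The expected step is a 1.3-fold higher number from compound 1 to compound 3 (0.10 log units; within the scatter).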

Compound 3, half-maximal inhibitory concentration: 1140 nM
The estimate for compound 3 lay 1.2-fold (0.09 log units) above the measured number, within the range that was stated.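

In this assay, the 4-(trifluoromethyl)phenyl to 4-bromophenyl change gives a 1.0-fold higher number from compound 1 to compound 3 (0.01 log units; within the scatter), the first step measured at this position. On the aromatic carbon, a group of 4 heavy atoms can thus be exchanged for a single bromine with no change beyond the scatter. Nothing shown here explains why these two groups read alike.

Going by these compounds, both groups have no hydrogen-bond donors or acceptors, so an amine or a carboxylic acid at this place remains untested here. On these data alone, whether such groups would keep this level of cytotoxicity stays open.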